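Benzylic urea series: switching the aryl to thiophen-2-yl

This account rests on a few compounds, and the source may have more. Where it says the series, first, only, none or still open, it means among the compounds named here.

Compound 1, `COc1cccc(CNC(=O)N2C(=O)c3ccccc3S2(=O)=O)c1`, in a physicochemical assay for pharmacokinetics; on this read-out lower numbers stand for a shorter-lived compound and higher numbers for a longer-lived compound: > 166 h, a limit of the assay.
Compound 2, `O=C(NCc1ccc(C(F)(F)F)cc1)N1C(=O)c2ccccc2S1(=O)=O`, in this assay: > 166 h, a limit of the assay.
Compound 3, `O=C(NCC1CCCCC1)N1C(=O)c2ccccc2S1(=O)=O`, in this assay: > 166 h, a limit of the assay.

Compound 1 stands only at a limit in this assay, and the other two values shown are limits as well; all three sit at the limit of > 166 h in this assay, at which 3 of the 3 values shown sit. For the measured compounds named here, the one single-point step among them, a step that the two limits leave unreadable from compound 1 to compound 3, cannot be read in size or direction, since both ends are limits.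

Compound 4, `O=C(NCc1cccs1)N1C(=O)c2ccccc2S1(=O)=O`, has not yet been measured in this assay. It differs from compound 1 as follows: thiophen-2-yl in place of 3-methoxyphenyl on a saturated chain carbon bound to an amide-type nitrogen. The step from compound 1 to compound 3 bears on it only in that a change at the same place left the value at the limit. Going by the values given here, no measured step gives a readable size, so no direction beyond the scatter is expected for a step that the limit leaves unreadable from compound 1 to compound 4. Compound 4 is therefore estimated at 250 h, between 100 h and 700 h, most likely reported as a limit again.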

Compound 4, half-life: > 166 h
Compound 4 was reported as a limit; the forecaster's own chance of this, stated with the estimate: 80%; the middle value lies beyond the limit too.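

Compound 1, compound 3 and compound 4 all stand at a limit in this assay, so the steps from compound 1 and from compound 3 to compound 4 cannot be read: the limit of > 166 h in this assay, at which 4 of the 4 values shown sit.

The compounds shown leave open whether any change at this place shifts the half-life at all, and in which direction.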